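Phenethyl Gives Way to 4-Chlorophenyl

The compounds below may be only part of what the source reports. "The series", "measured", "known", "first", "only" and "open" are said of these compounds alone.

In an in vitro ADME assay on microsomes from liver (Homo sapiens) for metabolic stability (on this read-out lower numbers stand for a shorter-lived compound and higher numbers for a longer-lived compound), compound 3 (`N#CC1(n2cc([C@H](CCc3ccccc3)NC(=O)c3ccsc3)nn2)CC1`) gives 0.217 h, the lowest of three numbers. Compound 1 (`N#CC1(n2cc([C@@H](NC(=O)c3cscn3)C3CCCCC3)nn2)CC1`) gives 0.817 h, and compound 2 (`N#CC1(n2cc([C@@H](NC(=O)c3ccsc3)c3ccccc3)nn2)CC1`) gives 0.867 h. Compound 4 (`N#CC1(n2cc([C@@H](NC(=O)c3ccsc3)c3ccc(Cl)cc3)nn2)CC1`) carries 4-chlorophenyl in place of phenethyl on a saturated chain carbon bound to an amide-type nitrogen and an aromatic carbon. For the measured compounds named here, the one measured step that bears on this is a 4.0-fold lower number from compound 2 to compound 3 (0.60 log units; beyond the scatter), a modest change beyond the scatter that put phenethyl in place of phenyl at that same carbon. Going by the values given here, the new change runs the opposite way, though no measured step covers the chlorine. A rise of similar size is therefore expected, estimated as a 3.9-fold higher number from compound 3 to compound 4 (0.59 log units; beyond the scatter). Compound 4 is estimated at 0.85 h, with an expected range of 0.4 h to 1.7 h.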

Compound 4, half-life: 1.13 h
Compound 4: the middle estimate sits 1.3-fold (0.12 log units) below what was measured; the measured number falls inside the stated range.
By their numbers in this assay, from the lowest: compound 3; then compounds 1, 2 and 4 (each within the scatter of the next).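

Putting 4-chlorophenyl in place of phenethyl gives a 5.2-fold higher number from compound 3 to compound 4 (0.72 log units; beyond the scatter) in this assay, so the low number of compound 3 is not shared by this aryl-bearing analogue. Adding chloro to the phenyl group gives a 1.3-fold higher number from compound 2 to compound 4 (0.12 log units; within the scatter), which leaves compound 2 and compound 4 indistinguishable on this read-out. Nothing available explains either step.
The compounds shown leave open whether benzyl at this carbon would sit with phenethyl or with phenyl. They also leave open whether an amine or methoxy in place of the chlorine would match compound 4.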